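This account rests on a few compounds, and the source may have more. Where it says the series, first, only, none or still open, it means among the compounds named here.

Measured to date in a functional assay for inhibition of sodium/hydrogen exchanger (Oryctolagus cuniculus); on this read-out lower numbers stand for stronger inhibition and higher numbers for weaker inhibition:

compound 1 `CS(=O)(=O)c1cc(C(=O)N=C(N)N)c(Cl)cc1Cl` gives 140 nM
compound 2 `CCc1cc(C)c(C(=O)N=C(N)N)cc1S(C)(=O)=O` gives 4.8 nM

Compound 2 holds the lowest of the two numbers; compound 1 sits higher in this assay, and the gap between the two lies beyond the scatter of repeated measurements. The two structures differ in more than one place, so nothing further is taken from the pair than what the two values show.

The next compound to be measured is compound 3 `Cc1cc(SC(C)(C)C)c(S(C)(=O)=O)cc1C(=O)N=C(N)N`. It departs from compound 2 in a single place: (tert-butyl)sulfanyl in place of ethyl on an aromatic carbon.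

Going by the values given here, no step between measured compounds isolates a change of this kind, so the expectation rests on the change itself and on the value of compound 2. A step of modest size is expected in this assay, if any, with the number for compound 3 likely held near that of compound 2 or raised slightly, not beyond the scatter with any confidence. The estimated step from compound 2 to compound 3 is a 1.5-fold higher number from compound 2 to compound 3 (0.16 log units; within the scatter). Compound 3 is thus estimated at 7 nM, with a range from 2 nM to 30 nM.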

Compound 3, half-maximal inhibitory concentration: 22 nM
The estimate for compound 3 lay 3.1-fold (0.50 log units) below the measured number; the range from low to high includes it.
By their numbers in this assay, from the lowest: compound 2; then compound 3; then compound 1.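

In this assay, going by these compounds alone, this carbon, ortho to the methylsulfonyl group and para to the group of 6 heavy atoms, is the first position with a single-place change, and (tert-butyl)sulfanyl in place of ethyl gives a 4.6-fold higher number from compound 2 to compound 3 (0.66 log units; beyond the scatter). The step lies beyond the scatter but is modest, so this position accepts a group of 5 heavy atoms in place of one of 2 with only a limited loss of inhibition, at least for this one pair. No data in hand bear on what lies behind the step.

The change brings in a sulfur atom and more carbon at once, and the two compounds cannot separate the contribution of the sulfur link from that of the branched tert-butyl end. Going by these compounds, what a methylsulfanyl group, a tert-butyl group set directly on the aromatic carbon, or an amine gives at this carbon stays open, as does whether the step holds with a group other than methyl at the carbon meta to this position.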